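The source may hold more compounds than are shown below. What is called first, only, known or untested is meant among the compounds shown, and "the series" means these compounds.

In a functional assay on NCI-H1299 cells (Homo sapiens) for antiproliferative activity, read by MTT assay, with a stated time of 24 h (a higher number here means a weaker inhibitor, a lower number a stronger inhibitor), compound 1 `COc1cc(/C=C/C(=O)NNC(=O)c2ccccc2)ccc1O` gives 6160 nM and compound 2 `COc1ccc(C(=O)NNC(=O)/C=C/c2ccc(O)c(OC)c2)cc1` gives 5420 nM. Compound 3 `COc1cc(/C=C/C(=O)NNC(=O)c2ccccc2)cc(OC)c1O` reads > 10000 nM, which is a limit of the assay and not a number. Compound 4 `COc1ccc(C(=O)NNC(=O)/C=C/c2cc(OC)c(O)c(OC)c2)cc1` differs from compound 3 in one place: methoxy in place of hydrogen on an aromatic carbon. This is methoxy in place of hydrogen on an aromatic carbon, para to a large group, turning phenyl into 4-methoxyphenyl. The same change gave a 1.1-fold lower number from compound 1 to compound 2 (0.06 log units; within the scatter), so no step beyond the scatter is expected in this assay. The other methoxy step, at a different place, bears less directly: an at least 1.6-fold higher number from compound 1 to compound 3 (0.21 log units; that floor lies within the scatter). The estimated step is a step that the limit leaves unreadable from compound 3 to compound 4. For compound 4 the estimated value is 11000 nM, with an expected range from 6000 nM to 25000 nM.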

Compound 4, half-maximal inhibitory concentration: 7450 nM
Beside the measured number, compound 4's estimate is 1.5-fold (0.17 log units) above it, within the range that was stated.
By their numbers in this assay, from the lowest: compounds 2, 1 and 4 (each within the scatter of the next). At a limit, above all of these: compound 3.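

In this assay, the change to 4-methoxyphenyl now also appears on the core of compound 3, giving an at least 1.3-fold lower number from compound 3 to compound 4 (0.12 log units; that floor lies within the scatter), a floor rather than a full step: the same change on two cores in this assay, a 1.1-fold lower number (0.06 log units; within the scatter) from compound 1 to compound 2 and an at least 1.3-fold lower number (0.12 log units; that floor lies within the scatter) from compound 3 to compound 4; the limit leaves it open whether they differ

The other methoxy change, read on the core of compound 2, gives a 1.4-fold higher number from compound 2 to compound 4 (0.14 log units; within the scatter), its first reading free of a limit: the same change on two cores in this assay, an at least 1.6-fold higher number (0.21 log units; that floor lies within the scatter) from compound 1 to compound 3 and a 1.4-fold higher number (0.14 log units; within the scatter) from compound 2 to compound 4; the limit leaves it open whether they differ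

The compounds shown leave open whether an amine or a carboxylic acid in place of the methoxy of the 4-methoxyphenyl group would move the number beyond the scatter. They also leave open what a longer chain on that oxygen would do.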